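A few compounds are considered here, and "the series" means these few. Any claim that something is new, unique, unknown or untested is made for them only; others in the source may bear on it.

Compound 2 `Cc1ccc2c(c1)/C(=N/NC(=S)N/N=C/c1c(F)cccc1Cl)C(=O)N2` is the point of departure. In a functional assay on COS-7 cells (Chlorocebus aethiops) for inhibition, read by MTT assay (on this read-out higher numbers stand for weaker inhibition and lower numbers for stronger inhibition), compound 2 gives 2190 nM. Among the three measured compounds this is the lowest of the numbers, yet both neighbours sit within the usual scatter of it: compound 1 `COc1ccc(/C=N/NC(=S)N/N=C2\C(=O)Nc3ccc(C)cc32)cc1O` gives 3190 nM in this assay, and compound 3 `O=C1Nc2ccc(Br)cc2/C1=N/NC(=S)N/N=C/c1c(F)cccc1Cl` gives 2560 nM. Both measured steps are small: a 1.5-fold lower number from compound 1 to compound 2 (0.16 log units; within the scatter), and a 1.2-fold higher number from compound 2 to compound 3 (0.07 log units; within the scatter). Neither touches the place where compound 4 `Cc1ccc2c(c1)/C(=N/NC(=S)N/N=C/c1c(Cl)cccc1Cl)C(=O)N2` differs. That change is chloro in place of fluoro on an aromatic carbon, so that one bond further out the difference reads 2-chloro-6-fluorophenyl to 2,6-dichlorophenyl. For the measured compounds named here, no measured step exchanges these two halogens, so the expectation rests only on the observation that the exchanges seen so far, including the one that replaced the whole ring in compound 1, moved the numbers by little. Compound 4 is therefore expected to move by a 1.1-fold lower number from compound 2 to compound 4 (0.04 log units; within the scatter), a step not beyond the scatter. Compound 4 is estimated at 2000 nM, with a range from 900 nM to 4500 nM.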

Compound 4, half-maximal inhibitory concentration: 3870 nM
Estimate against measurement, compound 4: 1.9-fold (0.29 log units) below, within the range that was stated.
By their numbers in this assay, from the lowest: compounds 2, 3, 1 and 4 (each within the scatter of the next).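

In this assay, the exchange of fluoro for chloro on this aromatic carbon, ortho to a large group, gives a 1.8-fold higher number from compound 2 to compound 4 (0.25 log units; within the scatter), so this place on the ring now has a measured step of its own and that step stays within the scatter. Setting 2,6-dichlorophenyl in place of 3-hydroxy-4-methoxyphenyl gives a 1.2-fold higher number from compound 1 to compound 4 (0.08 log units; within the scatter), so these two rings cannot be told apart on this read-out, just as the 2-chloro-6-fluorophenyl ring could not be told apart from 3-hydroxy-4-methoxyphenyl. Nothing among the data shown offers an explanation for these small steps.

Going by these compounds, it remains open whether an amine or a carboxylic acid on this aromatic carbon would give a step beyond the scatter. On these data alone, it also remains open whether the bromo group of compound 3 would leave the number within the scatter when paired with the 2,6-dichlorophenyl ring.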